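The source may hold more compounds than are shown below. What is called first, only, known or untested is meant among the compounds shown, and "the series" means these compounds.

Going by the values given here, compound 2 `Fc1ccc(-c2cn3ccnc3c(-c3ccc4ncn(C5CCCCC5)c4c3)n2)cc1` is one of two compounds measured in a functional assay on MCF7 cells (Homo sapiens) for inhibition, read by sulforhodamine B assay, with a stated time of 48 h, tested at 10 uM; on this read-out higher numbers stand for more inhibition at the one concentration tested (going by the name of the read-out) and lower numbers for less inhibition. It stands lowest of the two numbers measured there: in this assay compound 2 gives 9.17%, while compound 1 `Brc1cn2ccnc2c(-c2ccc3ncn(C4CCCCC4)c3c2)n1` gives 47.6%. Among the compounds with values here, the one step recorded between them, a number 38.4 percentage points lower from compound 1 to compound 2 (beyond the scatter), came with 4-fluorophenyl in place of bromo on an aromatic carbon and is beyond the scatter.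

Compound 3 `COc1ccccc1-c1cn2ccnc2c(-c2ccc3ncn(C4CCCCC4)c3c2)n1` has not yet been measured in this assay. It differs from compound 2 as follows: 2-methoxyphenyl in place of 4-fluorophenyl on an aromatic carbon. Within the data shown here, the change keeps an aryl group on the same aromatic carbon, so the measured step from compound 1 to compound 2, which exchanged a bromo for an aryl group, bears on it only loosely; no step between two aryl groups at this place has been measured. On that basis compound 3 is expected to stay near the low level of compound 2, with a number 5.8 percentage points higher from compound 2 to compound 3 (within the scatter) expected to lie within the scatter. Compound 3 is therefore estimated at 15%, with a range from 0% to 40%.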

Compound 3, a percentage reported as inhibition, at one concentration (the size of the read-out at that concentration, not a potency): 8.4%
Compound 3: middle estimate off by 6.6 percentage points, on the high side; the measured number falls inside the stated range.
By their numbers in this assay, from the lowest: compounds 3 and 2 (each within the scatter of the next); then compound 1.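

In this assay, 2-methoxyphenyl in place of 4-fluorophenyl on this aromatic carbon gives a step within the scatter (a number 0.8 percentage points lower from compound 2 to compound 3 (within the scatter)), so these two aryl groups cannot be told apart here, even though the entering group carries a hydrogen-bond acceptor and the leaving group carries none. The change from bromo now has a second example (a number 39.2 percentage points lower from compound 1 to compound 3 (beyond the scatter)) alongside the earlier one (a number 38.4 percentage points lower from compound 1 to compound 2 (beyond the scatter)), so the large step away from compound 1 is not confined to 4-fluorophenyl, and neither aryl compound shown goes against it. Nothing given here explains why bromo and these aryl groups read so differently.

On these data alone, whether the higher reading of compound 1 is particular to bromo, or would also appear with a small group such as chloro or with an amine such as morpholine on this carbon, stays open. As far as these compounds go, it also stays open whether any aryl group at this place could lift the reading, for instance a phenyl ring bearing a carboxylic acid or an aminomethyl group.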